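The source may report more compounds than this note shows. Statements on the series, on what has been measured and on what is new or still open speak of the compounds shown alone.

The three measured compounds share one core and differ only in the group carried on the sulfur of the chain. In a functional assay on MCF7 cells (Homo sapiens) for cytotoxicity, read by MTT assay, with a stated time of 24 h, tested at 6.4 ug/mL (on this read-out higher numbers stand for a stronger effect at the one concentration tested and lower numbers for a weaker effect), compound 1 `Cn1c(-c2ccc(NC(=O)CSc3nc4ccccc4o3)cc2)nc(-c2ccccc2)c1-c1ccccc1` gives 42.3%, compound 2 `Cn1c(-c2ccc(NC(=O)CSc3nc4cc(Cl)ccc4o3)cc2)nc(-c2ccccc2)c1-c1ccccc1` gives 27.7%, and compound 3 `Cc1ccc2oc(SCC(=O)Nc3ccc(-c4nc(-c5ccccc5)c(-c5ccccc5)n4C)cc3)nc2c1` gives 24.6%. Compound 3 thus holds the lowest of the three numbers; compound 2 sits close to it within the scatter, whereas the step of a number 17.7 percentage points lower from compound 1 to compound 3 (beyond the scatter) lies beyond it, as does a number 14.6 percentage points lower from compound 1 to compound 2 (beyond the scatter). Compound 4 `Cn1c(-c2ccc(NC(=O)CSc3nc4ccccc4s3)cc2)nc(-c2ccccc2)c1-c1ccccc1` has not yet been measured. Its change from compound 3 is 1,3-benzothiazol-2-yl in place of 5-methyl-1,3-benzoxazol-2-yl on a sulfur. Two things happen at once: the methyl is lost and the ring oxygen is replaced by sulfur. Only the first has a measured counterpart, namely the reverse of a number 17.7 percentage points lower from compound 1 to compound 3 (beyond the scatter), which points to a return toward the number of compound 1. The ring exchange has no measured counterpart among these compounds, so its contribution cannot be sized, and the range is set wide. The account therefore expects compound 4 to move upward by a number 13.4 percentage points higher from compound 3 to compound 4 (beyond the scatter) in this assay. Compound 4 is expected to give 38%, somewhere between 22% and 54%.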

Compound 4, a percentage reported as activity, at one concentration (the size of the read-out at that concentration, not a potency): 27%
The estimate for compound 4 lay 11 percentage points above the measured number; measured number inside the range.
By their numbers in this assay, from the lowest: compounds 3, 4 and 2 (each within the scatter of the next); then compound 1.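

In this assay, going by these compounds alone, the step of a number 15.3 percentage points lower from compound 1 to compound 4 (beyond the scatter) is the first to isolate the exchange of 1,3-benzoxazol-2-yl for 1,3-benzothiazol-2-yl on this sulfur. The methyl that complicated the comparison with compound 3 plays no part here, and the step shows that this ring exchange alone separates the two numbers by more than the scatter. The other two steps, a number 2.4 percentage points higher from compound 3 to compound 4 (within the scatter) and a number 0.7 percentage points lower from compound 2 to compound 4 (within the scatter), place compound 4 level with the two substituted benzoxazoles, so among the four compounds all three changes made to the group of compound 1, namely chloro, methyl and the ring exchange, end in one cluster that cannot be ordered, with none going against this pattern. The data offer no explanation for why these different changes arrive at the same level.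

From the compounds shown here alone, what a chloro or methyl would do on the 1,3-benzothiazol-2-yl group itself stays open, as does the reading for a methoxy group there or for an amine or a carboxylic acid in place of the ring on the sulfur. With a single concentration behind each number, the compounds also leave open whether these steps would hold as a stronger or weaker effect at other concentrations.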